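The compounds below may be only part of what the source reports. "The series", "measured", "known", "first", "only" and "open" are said of these compounds alone.

Measured compounds in a functional assay on A549 cells (Homo sapiens) for antiproliferative activity, read by CCK-8 assay, with a stated time of 72 h; on this read-out lower numbers stand for stronger inhibition of growth and higher numbers for weaker inhibition of growth:

compound 1, `CCC1C(=O)N(C)c2cnc(Nc3ccc(S(=O)(=O)NCC(C)C)cc3)nc2N1c1ccn(C)n1`: 31600 nM
compound 2, `CCCNS(=O)(=O)c1ccc(Nc2ncc3c(n2)N(c2ccn(C)n2)C(CC)C(=O)N3C)cc1`: 15000 nM
compound 3, `CCCNC(=O)c1ccc2c(ccn2-c2ncc3c(n2)N(c2ccn(C)n2)C(CC)C(=O)N3C)c1`: "not active" (no number reported)

Within this set the only counted step is a 2.1-fold higher number from compound 2 to compound 1 (0.32 log units; beyond the scatter), made by the change (methyl in place of hydrogen on a saturated chain carbon bound to two saturated chain carbons). Compound 3 carries a core of its own; the difference between the two cores is not broken down here. Compound 4, `CCCCNC(=O)c1ccc2c(ccn2-c2ncc3c(n2)N(c2ccn(C)n2)C(CC)C(=O)N3C)c1`, is not yet measured and differs from compound 3 by methyl in place of hydrogen on a saturated chain carbon, three bonds along the chain from an amide-type nitrogen. Among the compounds with values here, this is the same kind of change as the one from compound 2 to compound 1, not the same: there the methyl enters on a saturated chain carbon bound to two saturated chain carbons, here on a saturated chain carbon, three bonds along the chain from an amide-type nitrogen, so the earlier step sets only a loose reference. Compound 3 gives no number in this assay, and the reference step is modest, so for compound 4 the expectation is weak growth inhibition at best. Compound 4 is estimated at 40000 nM, expected range 15000 nM to 100000 nM.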

Compound 4, concentration for 50% growth inhibition: 37300 nM
The estimate for compound 4 lay 1.1-fold (0.03 log units) above the measured number, and the stated range covers the measured number.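

Within the data shown here, no step from compound 3 to compound 4 can be read in this assay: compound 3 is reported as "not active" without a number, while compound 4 gives 37300 nM. The compounds shown leave open how growth inhibition on this core follows the amide chain from propyl to butyl. No evidence bears on this result.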